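The source may report more compounds than this note shows. Statements on the series, on what has been measured and on what is new or still open speak of the compounds shown alone.

Measured in a functional assay on MCF7 cells (Homo sapiens) for cytotoxicity, read by MTT assay, with stated times of 6 h and 48 h; on this read-out higher numbers stand for weaker inhibition and lower numbers for stronger inhibition:
- compound 1 `COc1ccc(C(=O)/C=C/c2cc(Br)c(Br)n2C)c(OC)c1`: 80 nM
- compound 2 `COc1ccc(OC)c(C(=O)/C=C/c2cc(Br)c(Br)n2C)c1`: 650 nM
- compound 3 `Cn1c(/C=C/C(=O)c2cccc(N)c2)cc(Br)c1Br`: 12400 nM

Compound 1 has the lowest number of the three, so it inhibits most strongly, and the gaps to compound 2 and compound 3 both lie beyond the scatter. Compound 4 `COc1ccc(C(=O)/C=C/c2cc(Br)c(Br)[nH]2)c(OC)c1` is compound 1 with hydrogen in place of methyl on an aromatic nitrogen. For the measured compounds named here, no measured pair shows this change on its own, so any forecast is uncertain. A moderate step towards weaker inhibition in this assay seems most likely, probably beyond the scatter, though a step within it remains possible. The expected change is a 3.1-fold higher number from compound 1 to compound 4 (0.49 log units; beyond the scatter). For compound 4 the estimated value is 250 nM, with an expected range of 60 nM to 1500 nM.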

Compound 4, half-maximal inhibitory concentration: 30 nM
For compound 4 the middle estimate is 8.3-fold (0.92 log units) above the measured one; the whole stated range lies above it.
By their numbers in this assay, from the lowest: compound 4; then compound 1; then compound 2; then compound 3.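

For the compounds shown here, replacing methyl with hydrogen on the aromatic nitrogen gives a 2.7-fold lower number from compound 1 to compound 4 (0.43 log units; beyond the scatter) in this assay, the first direct reading of this change. On the core of compound 1, the methyl is therefore not needed for strong inhibition, and its removal gives a modest gain. Nothing measured here offers a reason for this step.

On these data alone, whether an ethyl group or a longer chain on this nitrogen would weaken inhibition stays open. So does whether hydrogen would give a similar gain with the differently substituted ketone-side rings of compound 2 and compound 3.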